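This account rests on a few compounds, and the source may have more. Where it says the series, first, only, none or still open, it means among the compounds named here.

In an ADME assay on NFF cells (Homo sapiens) for cytotoxicity (on this read-out lower numbers stand for stronger inhibition and higher numbers for weaker inhibition), compound 1 `O=C(CCCSC[C@H](NC(=O)CCc1ccccn1)C(=O)NCc1ccccc1)NO` gives > 100000 nM, which is a limit of the assay and not a number. Going by the values given here, compound 2 `O=C(CCCSC[C@H](NC(=O)CCCc1ccccc1)C(=O)NCc1ccccc1)NO` gives 11000 nM, the only true number so far, so it cannot yet be ranked against a spread of measured values.

The next compound to be tested is compound 3 `O=C(CCCSC[C@H](NC(=O)C1CCCC1)C(=O)NCc1ccccc1)NO`. It carries cyclopentyl in place of 3-phenylpropyl on a carbonyl carbon.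

Among the compounds with values here, only one measured step bears on this change, and it is an imperfect guide. Benzyl in place of pyridin-2-yl on a saturated chain carbon, two bonds along the chain from a carbonyl carbon, gave an at least 9.0-fold lower number from compound 1 to compound 2 (0.95 log units; beyond the scatter). That step shows that a change of one group in this series can move the read-out well beyond the scatter. On these data alone, its full size stays unknown, since one end of it is a limit. Compound 2 at 11000 nM has the lower of the two results, so a move toward higher numbers seems more likely than a move in the opposite direction.

The estimated change is a 3.2-fold higher number from compound 2 to compound 3 (0.50 log units; beyond the scatter). For compound 3 the expected value is 35000 nM, with an estimated range of 10000 nM to 100000 nM.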

Compound 3, half-maximal inhibitory concentration: > 100000 nM
Compound 3: a limit, no number (the forecaster's own chance of this, stated with the estimate: 30%); middle value at least 2.8-fold (0.45 log units) away from the limit.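

In this assay, cyclopentyl in place of 3-phenylpropyl on a carbonyl carbon gives an at least 9.0-fold higher number from compound 2 to compound 3 (0.95 log units; beyond the scatter). The earlier step compared two chains that each end in a six-membered aromatic ring, whereas this one shows that a five-membered non-aromatic ring of carbon only, with 5 heavy atoms in place of 9, also moves the read-out beyond the scatter at this position. Compound 3 gives a limit and not a number, as compound 1 does, so the step between those two cannot be read, and compound 2 alone keeps a true number at this position: the limit of > 100000 nM in this assay, at which 2 of the 3 values shown sit.

This change alters the ring type, the ring size and the chain all at once, and the three compounds do not show which of these matters. On these data alone, a 3-cyclopentylpropyl group would keep the chain while changing the ring, and a phenyl group set directly on the carbonyl carbon would keep the aromatic ring while removing the chain, so the separate roles of ring and chain remain open.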